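From ethylpiperazine to methoxyindoline: an expected modest change

A few compounds are considered here, and "the series" means these few. Any claim that something is new, unique, unknown or untested is made for them only; others in the source may bear on it.

Compound 1 `CCN1CCN(C(=S)SCC(=O)N(Cc2ccc(OC)cc2)c2cc(OC)c(OC)c(OC)c2)CC1`: 3070 nM
Compound 2 `COc1ccc(CN(C(=O)CSC(=S)N2CCN(C(=O)OC(C)(C)C)CC2)c2cc(OC)c(OC)c(OC)c2)cc1`: 250 nM
Compound 3 `COc1ccc(CN(C(=O)CSC(=S)N2CCc3ccccc32)c2cc(OC)c(OC)c(OC)c2)cc1`: 6940 nM

In a functional assay on KYSE-450 cells (Homo sapiens) for inhibition, read by CCK-8 assay, with a stated time of 48 h (a higher number here means a weaker inhibitor, a lower number a stronger inhibitor), compound 1 gives 3070 nM, the second highest of the three numbers. Compound 4 `COc1ccc(CN(C(=O)CSC(=S)N2CCc3cc(OC)ccc32)c2cc(OC)c(OC)c(OC)c2)cc1` has not yet been measured. It differs from compound 1 by a single exchange on a thiocarbonyl carbon: 5-methoxy-2,3-dihydro-1H-indol-1-yl in place of 4-ethylpiperazin-1-yl on a thiocarbonyl carbon. The closest guide is a 2.3-fold higher number from compound 1 to compound 3 (0.35 log units; beyond the scatter), a modest step, where 2,3-dihydro-1H-indol-1-yl replaced 4-ethylpiperazin-1-yl. The large 12-fold lower number from compound 1 to compound 2 (1.09 log units; beyond the scatter) came from tert-butoxycarbonyl replacing ethyl, a different change, so it offers little guidance. The effect of the added methoxy has not been measured on its own. A modest step towards a higher number is therefore expected in this assay. The estimate for compound 4 is 5000 nM, with an expected range of 1500 nM to 15000 nM. This estimate means an expected 1.6-fold higher number from compound 1 to compound 4 (0.21 log units; within the scatter).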

Compound 4, half-maximal inhibitory concentration: 10200 nM
Compound 4: the middle estimate sits 2.0-fold (0.31 log units) below what was measured, within the range that was stated.
By their numbers in this assay, from the lowest: compound 2; then compound 1; then compounds 3 and 4 (each within the scatter of the next).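

In this assay, 5-methoxy-2,3-dihydro-1H-indol-1-yl in place of 4-ethylpiperazin-1-yl on the thiocarbonyl carbon gives a 3.3-fold higher number from compound 1 to compound 4 (0.52 log units; beyond the scatter), so the weakening seen with the unsubstituted group holds with the methoxy present. The methoxy alone, in place of hydrogen on an aromatic carbon, gives a 1.5-fold higher number from compound 3 to compound 4 (0.17 log units; within the scatter), so this one change shows no clear effect. No measurement shown explains either step.

Still open, from the compounds shown here alone, is how a hydroxyl or a fluorine would read in place of that methoxy, and how a piperidine would read on the thiocarbonyl carbon.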